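Replacing a Chain Group on a Lactam Nitrogen

The source may hold more compounds than are shown below. What is called first, only, known or untested is meant among the compounds shown, and "the series" means these compounds.

compound 1 `O=C1[C@@H](NS(=O)(=O)c2cc3ccnc(Cl)c3s2)CCN1CCNc1ccncc1`: 23%
compound 2 `O=C1[C@@H](NS(=O)(=O)c2ccc(-c3ccc(Cl)s3)s2)CCN1Cc1cc2[nH]cccc-2n1`: 42%

In an assay on isolated protein for inhibition of coagulation factor X (Oryctolagus cuniculus), tested at 1 uM (a lower number here means less inhibition, a higher number more inhibition at the concentration tested (going by the name of the read-out)), compound 1 gives 23%, the lower of the two numbers. Compound 2 gives 42%, a gap beyond the usual scatter. Compound 3 `O=C1[C@@H](NS(=O)(=O)c2cc3ccnc(Cl)c3s2)CCN1Cc1cc2c[nH]ccc-2n1` is not yet measured. It differs from compound 1 in one place: a group of 9 heavy atoms (7 carbon, 2 nitrogen; one five-membered aromatic ring with 1 hetero atom, one six-membered aromatic ring with 1 hetero atom) in place of a group of 8 heavy atoms (6 carbon, 2 nitrogen; one six-membered aromatic ring with 1 hetero atom), on a saturated chain carbon bound to an amide-type nitrogen in a ring. For the measured compounds named here, no measured pair shows this change alone, so its direction is open. A modest rise is expected, with a number 12 percentage points higher from compound 1 to compound 3 (beyond the scatter), of a size near the edge of the scatter. Compound 3 is estimated at 35% in this assay, with a range from 15% to 60%.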

Compound 3, a percentage reported as inhibition, at one concentration (the size of the read-out at that concentration, not a potency): 25%
Compound 3: middle estimate off by 10 percentage points, on the high side, and the stated range covers the measured number.
By their numbers in this assay, from the lowest: compounds 1 and 3 (each within the scatter of the next); then compound 2.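

In this assay, placing the group with a five-membered and a six-membered aromatic ring where ((pyridin-4-yl)amino)methyl stood gives a number 2 percentage points higher from compound 1 to compound 3 (within the scatter). On the core of compound 1, the two groups therefore cannot be told apart at this position, even though their ring content differs. No measurement shown explains this result.

As far as these compounds go, whether a plain phenyl ring, a primary amine or a longer chain at this position would give a different number stays open. So does whether the two groups would also match on the core of compound 2.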